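From methoxy to dimethylamino on the shared core

The compounds below may be only part of what the source reports. "The series", "measured", "known", "first", "only" and "open" are said of these compounds alone.

In a functional assay, read by spectrophotometry, tested at 100 uM (on this read-out higher numbers stand for weaker inhibition and lower numbers for stronger inhibition), compound 1 (`O=C(/C=C/c1ccccc1)c1cccc(NC(=O)c2cc(-c3ccncc3)n[nH]2)c1`) gives 67100 nM and compound 2 (`COc1ccc(/C=C/C(=O)c2cccc(NC(=O)c3cc(-c4ccncc4)n[nH]3)c2)cc1`) gives 38400 nM. For the measured compounds named here, these are the only two numbers so far, and they lie within the scatter of each other, so compound 2 does not separate from compound 1.

Compound 3 (`CN(C)c1ccc(/C=C/C(=O)c2cccc(NC(=O)c3cc(-c4ccncc4)n[nH]3)c2)cc1`) carries dimethylamino in place of methoxy on an aromatic carbon, para to a large group: dimethylamino in place of methoxy on an aromatic carbon. Going by the values given here, the only measured step that bears on this change is a 1.7-fold lower number from compound 1 to compound 2 (0.24 log units; within the scatter), with methoxy in place of hydrogen on an aromatic carbon. Among the compounds with values here, no compound with dimethylamino has a measured value yet, so this one small step is the sole guide. No shift beyond the scatter is expected in this assay. The estimated step is a 1.1-fold lower number from compound 2 to compound 3 (0.04 log units; within the scatter). The expected value for compound 3 is 35000 nM, with a range of 14000 nM to 85000 nM.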

Compound 3, half-maximal inhibitory concentration: 41900 nM
Compound 3: middle estimate off by 1.2-fold (0.08 log units), on the low side; the measured number falls inside the stated range.
By their numbers in this assay, from the lowest: compounds 2, 3 and 1 (each within the scatter of the next).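

In this assay, dimethylamino in place of methoxy, on an aromatic carbon para to a large group, gives no readable change (a 1.1-fold higher number from compound 2 to compound 3 (0.04 log units; within the scatter)). Dimethylamino in place of hydrogen on the same carbon also stays within the scatter (a 1.6-fold lower number from compound 1 to compound 3 (0.20 log units; within the scatter)), so a second group now fails to separate from the unsubstituted compound. Hydrogen, methoxy and dimethylamino at this position therefore remain indistinguishable in this series, and no measurement offers an explanation for this.

On these data alone, whether any group at this position can move the number beyond the scatter remains open, for example a carboxylic acid, a trifluoromethyl group or a longer alkoxy chain. Also open, as far as these compounds go, is whether a change elsewhere on the shared core, such as replacing the amide hydrogen, would do so.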